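The source may report more compounds than this note shows. Statements on the series, on what has been measured and on what is new or still open speak of the compounds shown alone.

Of the compounds shown here, two with a shared core have been measured in an assay on isolated protein for inhibition of NUAK family SNF1-like kinase 1 (Homo sapiens), read by ADP-Glo, with a stated time of 60 min, tested at 10 uM, in the presence of a further agent that is not named here; a lower number here means less inhibition, a higher number more inhibition at the concentration tested (going by the name of the read-out). Compound 1, `CCC(=O)Nc1cccc(Oc2nc(Nc3ccc(N(C)C)cc3OC)ncc2Cl)c1`, gives 80.6% in this assay. Compound 2, `CCC(=O)Nc1cccc(Oc2nc(Nc3ccc(N4CCC(C)CC4)cc3OC)ncc2Cl)c1`, gives 9.2% in this assay. Of the two numbers, compound 2 stands lowest, with compound 1 the nearest and far higher; the step of a number 71.4 percentage points lower from compound 1 to compound 2 (beyond the scatter) lies well beyond the usual scatter. Compound 3, `CCCN(CCC)c1ccc(Nc2ncc(Cl)c(Oc3cccc(NC(=O)CC)c3)n2)c(OC)c1`, has not yet been measured. It differs from compound 2 in one place: dipropylamino in place of 4-methylpiperidin-1-yl on an aromatic carbon. Among the measured compounds shown here, the only step that bears on this change is the one from compound 1 to compound 2, which was large and downward when dimethylamino gave way to 4-methylpiperidin-1-yl. Compound 3 carries an acyclic group again, so a partial recovery toward compound 1 is expected, with wide uncertainty. The expected step for compound 3 is a number 20.8 percentage points higher from compound 2 to compound 3 (beyond the scatter). The estimate for compound 3 in this assay is 30%, with a range from 5% to 65%.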

Compound 3, a percentage reported as inhibition, at one concentration (the size of the read-out at that concentration, not a potency): "not active" (no number reported)
Compound 3 has no reported number here, so the estimate cannot be set against anything.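

Among the compounds shown here, compound 3 is recorded as "not active" in this assay, without a number, so no step between compound 2 and compound 3 can be read. No measurement shown bears on this result. The compounds shown leave open how compound 3, with dipropylamino, compares numerically with compound 2, with 4-methylpiperidin-1-yl.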